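The source may report more compounds than this note shows. Statements on the series, on what has been measured and on what is new or still open speak of the compounds shown alone.

Measured in a functional assay on MDA-MB-231 cells (Homo sapiens) for inhibition, read by CCK-8 assay, with a stated time of 48 h; on this read-out lower numbers stand for stronger inhibition of growth and higher numbers for weaker inhibition of growth:
Compound 1 `CN1CCN(c2ccc(Nc3ncc(Cl)c(NCc4ccccc4)n3)nc2)CC1`: 24800 nM
Compound 2 `COc1cccc(CNc2nc(Nc3ccc(N4CCN(C)CC4)cn3)ncc2Cl)c1`: 20300 nM

Compound 2 stands within the scatter of compound 1, so the two values do not separate. Compound 3 `CN1CCN(c2ccc(Nc3ncc(Cl)c(NCc4ccco4)n3)nc2)CC1` carries furan-2-yl in place of 3-methoxyphenyl on a saturated chain carbon bound to a nitrogen on an aromatic ring, counted as furan-2-yl in place of 3-methoxyphenyl on a saturated chain carbon bound to a nitrogen on an aromatic ring. Resting on a 1.2-fold lower number from compound 1 to compound 2 (0.09 log units; within the scatter), the one measured step that bears on this and one made on the aromatic ring that now leaves, no shift beyond the scatter is expected in this assay. Going by the values given here, no measured compound shows that ring replaced, so the support is thin. The expected move is a 1.1-fold higher number from compound 2 to compound 3 (0.03 log units; within the scatter), an estimate only. For compound 3 the estimated value is 22000 nM, with an expected range from 9000 nM to 50000 nM.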

Compound 3, concentration for 50% growth inhibition: 11000 nM
Beside the measured number, compound 3's estimate is 2.0-fold (0.30 log units) above it; the measured number falls inside the stated range.
By their numbers in this assay, from the lowest: compounds 3, 2 and 1 (each within the scatter of the next, the first and the last beyond it).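

Working from this assay, the ring on the saturated chain carbon bound to a nitrogen on an aromatic ring is now changed itself, and not only substituted: furan-2-yl in place of 3-methoxyphenyl gives a 1.8-fold lower number from compound 2 to compound 3 (0.27 log units; within the scatter) and so does not separate the two, even with 5 heavy atoms entering and 8 leaving. Against the unsubstituted phenyl, the same ring gives a 2.3-fold lower number from compound 1 to compound 3 (0.35 log units; beyond the scatter) as the first step in the series beyond the scatter, though a modest one. No measurement shown accounts for this step.

Furan-2-yl differs from phenyl in both ring size and hetero atom, so these two changes remain unseparated. Also open, from the compounds shown here alone, is how thiophen-2-yl, tetrahydrofuran-2-yl or a longer chain to the ring would read out at this place.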